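Fluoro in place of methyl on the pendant phenyl

This account rests on a few compounds, and the source may have more. Where it says the series, first, only, none or still open, it means among the compounds named here.

Compound 2 `COc1cc2c(Oc3ccc(NC(=O)c4cc(-c5ccc(C)cc5)ccn4)cc3F)ccnc2cc1OCCCN1CCCC1` gives 160 nM in a functional assay on NCI-H460 cells (Homo sapiens) for cytotoxicity, read by MTT assay, with a stated time of 72 h; on this read-out higher numbers stand for weaker inhibition and lower numbers for stronger inhibition. Going by the values given here, compound 1 `COc1cc2c(Oc3ccc(NC(=O)c4cc(-c5ccccc5)ccn4)cc3F)ccnc2cc1OCCCN1CCCC1` gives 130 nM in this assay; the step of a 1.2-fold higher number from compound 1 to compound 2 (0.09 log units; within the scatter) is within the scatter, so compound 2 stands together with compound 1 on the two numbers so far, with nothing to separate them. Compound 3 `COc1cc2c(Oc3ccc(NC(=O)c4cc(-c5ccc(F)cc5)ccn4)cc3F)ccnc2cc1OCCCN1CCCC1` differs from compound 2 by fluoro in place of methyl on an aromatic carbon, on an aromatic carbon of a six-membered aromatic ring of carbon only, para to a large group. Among the compounds with values here, the one measured step touching this carbon is a 1.2-fold higher number from compound 1 to compound 2 (0.09 log units; within the scatter), a change that stayed within the scatter; no step with fluoro at this carbon exists. A further single-atom substituent at the same carbon is therefore expected to leave this assay essentially unchanged, a step of a 1.1-fold lower number from compound 2 to compound 3 (0.06 log units; within the scatter) with no direction beyond the scatter. The estimate for compound 3 is 140 nM, with a range of 70 nM to 280 nM.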

Compound 3, half-maximal inhibitory concentration: 370 nM
Estimate against measurement, compound 3: 2.6-fold (0.42 log units) below, and the stated range ends below it.
By their numbers in this assay, from the lowest: compounds 1 and 2 (each within the scatter of the next); then compound 3.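

At this carbon, para to a large group, the substituent does matter in this assay: fluoro in place of methyl gives a 2.3-fold higher number from compound 2 to compound 3 (0.36 log units; beyond the scatter) and fluoro in place of hydrogen gives a 2.8-fold higher number from compound 1 to compound 3 (0.45 log units; beyond the scatter). The silence of the methyl step therefore does not extend to every single-atom substituent here: hydrogen and methyl stand together, while fluoro stands apart on the side of weaker inhibition, though only modestly. Nothing available bears on why fluoro parts from the other two.

On these data alone, it remains open whether this shift is peculiar to fluoro or would also appear with chloro, methoxy, an amine or a carboxylic acid at the same carbon. Also open, as far as these compounds go, is whether 4-fluorophenyl differs from phenyl in the same way in any read-out other than this cytotoxicity measure.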